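The source may report more compounds than this note shows. Statements on the series, on what has been measured and on what is new or still open speak of the compounds shown alone.

In a functional assay on HL-60 cells (Homo sapiens) for cytotoxicity, read by MTT assay, with a stated time of 48 h (a higher number here means a weaker inhibitor, a lower number a stronger inhibitor), three compounds sharing one core have been measured. Compound 1 `O=C(O)CN1C(=O)/C(=C/c2nc3ccccc3n2Cc2ccc(Br)cc2F)SC1=S` gives 6420 nM, compound 2 `N#Cc1ccc(Cn2c(/C=C3\SC(=S)N(CC(=O)O)C3=O)nc3ccccc32)cc1` gives 7640 nM, and compound 3 `Cc1ccc(Cn2c(/C=C3\SC(=S)N(CC(=O)O)C3=O)nc3ccccc32)cc1` gives 540 nM. Compound 3 therefore has the lowest number of the three and is the most potent of this small set. Compound 4 `O=C(O)CN1C(=O)/C(=C/c2nc3ccccc3n2Cc2ccc(F)cc2F)SC1=S` departs from it at one place, with 2,4-difluorophenyl in place of 4-methylphenyl on a saturated chain carbon bound to an aromatic nitrogen.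

The measured steps at this position bear directly on that change. Both routes to compound 3 are large: a 12-fold lower number from compound 1 to compound 3 (1.08 log units; beyond the scatter) and a 14-fold lower number from compound 2 to compound 3 (1.15 log units; beyond the scatter). By contrast, a 1.2-fold higher number from compound 1 to compound 2 (0.08 log units; within the scatter) stays within the scatter, so the two compounds without the 4-methylphenyl group sit close together. Compound 4 also gives up that group, and its ring carries fluorine, as does the 4-bromo-2-fluorophenyl of compound 1. Going by the values given here, no measured pair shows what fluorine in place of bromine does here, so the expectation stays wide. A clear rise in the number is expected, somewhat smaller than those large steps in size.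

The expected change is a 6.5-fold higher number from compound 3 to compound 4 (0.81 log units; beyond the scatter). For compound 4 the estimated value is 3500 nM, with an expected range from 1200 nM to 9000 nM.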

Compound 4, half-maximal inhibitory concentration: 6520 nM
Beside the measured number, compound 4's estimate is 1.9-fold (0.27 log units) below it, within the range that was stated.
By their numbers in this assay, from the lowest: compound 3; then compounds 1, 4 and 2 (each within the scatter of the next).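

In this assay, going by these compounds alone, 2,4-difluorophenyl in place of 4-methylphenyl on a saturated chain carbon bound to an aromatic nitrogen gives a 12-fold higher number from compound 3 to compound 4 (1.08 log units; beyond the scatter), so this change is as clearly beyond the scatter as the earlier steps involving compound 3. Within the data shown here, the pair the earlier compounds lacked now exists, and fluoro in place of bromo on an aromatic carbon gives a 1.0-fold higher number from compound 1 to compound 4 (0.01 log units; within the scatter), while 2,4-difluorophenyl in place of 4-cyanophenyl gives a 1.2-fold lower number from compound 2 to compound 4 (0.07 log units; within the scatter). Compounds 1, 2 and 4 thus form one group with no order among them, and compound 3 alone stands apart as the most potent of the four. Nothing available explains this separation.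

Among these compounds, with only one compound carrying 4-methylphenyl, it remains open whether a plain phenyl, 4-ethylphenyl or 4-methoxyphenyl at this place would keep a number near that of compound 3 or join the other three. On these data alone, all four compounds also share the carboxylic acid of the core, so what an ester or an amide there would do to these differences is equally open.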